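This account rests on a few compounds, and the source may have more. Where it says the series, first, only, none or still open, it means among the compounds named here.

Compound 1 `CC[C@H](C)[C@H](NC(=O)c1cccc(Cn2ccnc2)c1)C(=O)Nc1nccs1`: 4%
Compound 2 `CCCCNC(=O)[C@@H](NC(=O)c1cccc(Cn2ccnc2)c1)[C@@H](C)CC`: "not active" (no number reported)
Compound 3 `CCCCS(=O)(=O)NC(=O)[C@@H](NC(=O)c1cccc(Cn2ccnc2)c1)[C@@H](C)CC`: "not determined" (no result reported)

In an assay on HEK293 cells for displacement of a labelled ligand from Type-2 angiotensin II receptor (Homo sapiens), tested at 1 uM (on this read-out higher numbers stand for a stronger effect at the one concentration tested and lower numbers for a weaker effect), compound 1 gives 4%, compound 2 is reported as "not active" (no number reported), and compound 3 has no single number, its entry reading "not determined" (no result reported). Compound 2 is a further entry without a number, so compound 3 stands nowhere on the numbers shown. Compound 4 `CC[C@H](C)[C@H](NC(=O)c1cccc(Cn2ccnc2)c1)C(=O)NNS(=O)(=O)c1ccc(C)cc1` differs from compound 3 in one place: ((4-methylphenyl)sulfonyl)amino in place of butylsulfonyl on an amide-type nitrogen. Within the data shown here, no measured step covers this change, so its size in this assay is unknown; with compound 3 unmeasured, no direction can be read, and only a small reading, within the scatter of the low values seen, is expected for compound 4, because compound 1 gives 4% on the shared core. Compound 4 is estimated at 5% in this assay, expected to lie between 0% and 20%.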

Compound 4, a percentage reported as inhibition, at one concentration (the size of the read-out at that concentration, not a potency): 4%
Beside the measured number, compound 4's estimate is 1 percentage points above it, and the stated range covers the measured number.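

In this assay, putting ((4-methylphenyl)sulfonyl)amino in place of 1,3-thiazol-2-yl on an amide-type nitrogen gives no change at the digits printed from compound 1 to compound 4 (within the scatter). Among these compounds, this is the first readable step at this position, and it shows that two very different groups give the same low reading at the one concentration tested. Nothing available explains this result.

Steps involving compound 2 or compound 3 cannot be read, as neither compound has a number. On these data alone, whether a carboxylic acid or an amine on this nitrogen would raise the reading remains open.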